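A few compounds are considered here, and "the series" means these few. Any claim that something is new, unique, unknown or untested is made for them only; others in the source may bear on it.

Of the compounds shown here, three built on one shared core have so far been measured in a functional assay on HeLa cells (Homo sapiens) for inhibition, read by cell counting, with a stated time of 4 days; on this read-out lower numbers stand for stronger inhibition and higher numbers for weaker inhibition. Compound 1 `C=C(Br)C(=O)Nc1cccc(-c2cn3nc(CCc4ccccc4)sc3n2)c1` gives 3300 nM in this assay. Compound 3 `C=C(Br)C(=O)Nc1cccc(-c2cn3nc(Cc4ccc(Cl)cc4)sc3n2)c1` gives 2700 nM in this assay, and the step of a 1.2-fold lower number from compound 1 to compound 3 (0.09 log units; within the scatter) shows how little that change in the side chain matters. Compound 2 `Nc1cccc(-c2cn3nc(-c4ccc(F)cc4)sc3n2)c1` gives >= 250000 nM in this assay, and this value is a limit of the assay, not a number. Among the three values shown, compound 2 thus sits at the limit of >= 250000 nM in this assay, at which 1 of the 3 values shown sits.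

Compound 4 `Nc1cccc(-c2cn3nc(-c4ccc(Cl)cc4)sc3n2)c1` has not yet been measured. It differs from compound 2 only by chloro in place of fluoro on an aromatic carbon. Within the data shown here, the single measured step, a 1.2-fold lower number from compound 1 to compound 3 (0.09 log units; within the scatter), concerns a change on a saturated chain carbon rather than a swap of one halogen for another, so no measured step bears directly on the change from compound 2 to compound 4; that measured step itself stayed within the scatter. For compound 4 the expected step is therefore a number no higher from compound 2 to compound 4 (the limit leaves the size open), which amounts to no change beyond the scatter. Compound 4 is accordingly estimated to give 250000 nM in this assay, within a range from 100000 nM to 500000 nM, with the expectation that the assay will again report only a limit.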

Compound 4, half-maximal inhibitory concentration: 160000 nM
Compound 4: the middle estimate sits 1.6-fold (0.19 log units) above what was measured, and the stated range covers the measured number.
By their numbers in this assay, from the lowest: compounds 3 and 1 (each within the scatter of the next); then compound 4. At a limit, above all of these: compound 2.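

In this assay the swap of 4-fluorophenyl to 4-chlorophenyl gives an at least 1.5-fold lower number from compound 2 to compound 4 (0.19 log units; that floor lies within the scatter), the first step shown for a halogen on this aromatic ring, para to a large group. The earlier step concerned a saturated chain carbon, so it said nothing about this position, whereas here the chloro compound yields a measured number where the fluoro compound yielded none. Even so, the step gives only a floor, and that floor does not go beyond the scatter, so the size of the change remains unfixed and the value of compound 2 stays a limit of the assay, not a number: the limit of >= 250000 nM in this assay, at which 1 of the 4 values shown sits.

The compounds shown leave open whether a bromo, a methyl, a methoxy or a trifluoromethyl group in place of the chloro would shift the number in this assay, and whether any such group would give a step clearly beyond the scatter. They also leave open whether the same halogen swap would have any effect on compounds that carry the bromo-substituted amide of compound 1 in place of the free amine.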